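The source may report more compounds than this note shows. Statements on the series, on what has been measured and on what is new or still open speak of the compounds shown alone.

Of the compounds shown here, two have been measured in a functional assay on C6 cells (Rattus norvegicus) for cytotoxicity, read by MTT assay, with a stated time of 24 h, tested at 50 ug/mL; on this read-out higher numbers stand for a weaker effect at the one concentration tested and lower numbers for a stronger effect. Compound 1 `Cc1nnc(SCC(=O)N/N=c2/scc(-c3ccccc3)n2-c2ccccc2)s1` gives 63.9% in this assay. Within the data shown here, compound 2 `O=C(CSc1nnnn1-c1ccccc1)N/N=c1/scc(-c2ccc(Cl)cc2)n1-c1ccccc1`, the only other compound measured, gives 60% in this assay; the gap between the two numbers lies within the usual scatter, so neither compound can be set apart from the other on this read-out.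

Compound 3 `COc1ccc(-c2cs/c(=N/NC(=O)CSc3nnc(C)s3)n2-c2ccccc2)cc1` has not yet been measured in this assay. It differs from compound 1 in one place: methoxy in place of hydrogen on an aromatic carbon. Among the measured compounds shown here, no pair of measured compounds differing only in this way is available, so the size of the step cannot be drawn from the data. Given that compound 1 gives 63.9%, the step from compound 1 to compound 3 in this assay is expected to be small, a number 1.9 percentage points lower from compound 1 to compound 3 (within the scatter), in no clear direction and likely within the scatter. Compound 3 is therefore estimated at 62% in this assay, with a range from 42% to 82%.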

Compound 3, a percentage reported as activity, at one concentration (the size of the read-out at that concentration, not a potency): 31.5%
The estimate for compound 3 lay 30.5 percentage points above the measured number, outside the stated range (below it).
By their numbers in this assay, from the lowest: compound 3; then compounds 2 and 1 (each within the scatter of the next).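

In this assay the change from phenyl to 4-methoxyphenyl produces a large step, a number 32.4 percentage points lower from compound 1 to compound 3 (beyond the scatter) and towards a stronger effect at the one concentration tested. Among these compounds, this is the first sign that this aromatic carbon, para to a large group, is not indifferent to what it carries: a methoxy group of only 2 heavy atoms moves the read-out beyond the usual scatter. No measured property of these compounds bears on this step, so the data offer no explanation for it.

The compounds shown compare only hydrogen and methoxy at this carbon on this core, so it remains open whether the step is specific to methoxy. A hydroxyl group, an ethoxy group or a dimethylamino group at the same carbon would address that question.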